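Replacing isopropoxy with 4-methylphenyl on the amide carbonyl

The source may report more compounds than this note shows. Statements on the series, on what has been measured and on what is new or still open speak of the compounds shown alone.

The series shares one core carrying an amide-type nitrogen. Compound 1 `C/C=C/C(=O)Nc1c(C(O)(C(F)(F)F)C(F)(F)F)ccc2ccccc12` gives 72 nM in an assay on LtK cells with ATP-sensitive inward rectifier potassium channel 11 (Homo sapiens) as the target; a higher number here means that more compound is needed for the effect, a lower number that less compound is needed. Compound 2 `COCC(=O)Nc1c(C(O)(C(F)(F)F)C(F)(F)F)ccc2ccccc12` gives 213 nM, and compound 3 `CC(C)OC(=O)Nc1c(C(O)(C(F)(F)F)C(F)(F)F)ccc2ccccc12` gives 1160 nM. Compound 3 stands highest of the three, a 5.4-fold higher number from compound 2 to compound 3 (0.74 log units; beyond the scatter) and a 16-fold higher number from compound 1 to compound 3 (1.21 log units; beyond the scatter); between the other two, a 3.0-fold higher number from compound 1 to compound 2 (0.47 log units; beyond the scatter). Every change so far sits on the same carbonyl carbon, and the isopropoxy group of compound 3 gives the highest number among them.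

Compound 4 `Cc1ccc(C(=O)Nc2c(C(O)(C(F)(F)F)C(F)(F)F)ccc3ccccc23)cc1` has not yet been measured. It differs from compound 3 in one place: 4-methylphenyl in place of isopropoxy on a carbonyl carbon. Both measured steps into compound 3 bear on this change, since each swaps what the carbonyl carbon carries, and both were beyond the scatter. By that reading, leaving isopropoxy for a carbon-only group is expected to lower the number in this assay, roughly as far as compound 1 sits from compound 3. Compound 4 is therefore expected to give 120 nM, within 40 nM to 400 nM, an expected step of a 9.7-fold lower number from compound 3 to compound 4 (0.99 log units; beyond the scatter).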

Compound 4, half-maximal effective concentration: 76 nM
Beside the measured number, compound 4's estimate is 1.6-fold (0.20 log units) above it; low and high end bracket the measured number.
By their numbers in this assay, from the lowest: compounds 1 and 4 (each within the scatter of the next); then compound 2; then compound 3.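

In this assay, the change from isopropoxy to 4-methylphenyl on the carbonyl carbon brings a large drop (a 15-fold lower number from compound 3 to compound 4 (1.18 log units; beyond the scatter)), and the same group also improves on methoxymethyl (a 2.8-fold lower number from compound 2 to compound 4 (0.45 log units; beyond the scatter)). A six-membered aromatic ring of carbon only is thus accepted at this position and performs like prop-1-en-1-yl (a 1.1-fold higher number from compound 1 to compound 4 (0.02 log units; within the scatter)), so the two carbon-only groups cannot be told apart here, while the two oxygen-bearing groups, methoxymethyl and isopropoxy, both give higher numbers. Nothing shown offers a measured reason for these differences.

Going by these compounds, it remains open how plain phenyl, or a phenyl ring with a carboxylic acid in place of the methyl, would behave at this position. An amine on the carbonyl carbon, or a longer saturated carbon chain, is equally untested among the compounds shown.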